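Swapping the Fluorophenyl for a Pentyl Chain

The source may hold more compounds than are shown below. What is called first, only, known or untested is meant among the compounds shown, and "the series" means these compounds.

Three compounds have been measured in a functional assay on SK-OV-3 cells (Homo sapiens) for cytotoxicity, read by MTT assay, with a stated time of 48 h; on this read-out higher numbers stand for weaker inhibition and lower numbers for stronger inhibition:

compound 1 `CN(C)CCNc1ccnc2cc(OCc3ccc(F)cc3)ccc12` gives 890 nM
compound 2 `CN(C)CCCNc1ccnc2cc(OCc3ccc(F)cc3)ccc12` gives 1280 nM
compound 3 `CCOc1ccc2c(NCCCN(C)C)ccnc2c1` gives 6780 nM

Compound 1 has the lowest number of the three, though compound 2 sits within the scatter of it, as a 1.4-fold higher number from compound 1 to compound 2 (0.16 log units; within the scatter) shows. For the measured compounds named here, compound 3 stands clearly apart: the step of a 5.3-fold higher number from compound 2 to compound 3 (0.72 log units; beyond the scatter) is beyond the scatter and is the only measured change at the carbon next to the aromatic oxygen.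

The unmeasured compound 4 `CCCCCCOc1ccc2c(NCCN(C)C)ccnc2c1` differs from compound 1 at that same position: pentyl in place of 4-fluorophenyl on a saturated chain carbon bound to an oxygen on an aromatic ring. The nearest guide is the step from compound 2 to compound 3, where the 4-fluorophenyl also left and a methyl took its place, giving a modest rise in the number. Pentyl is a longer chain than methyl, so the outcome is uncertain, but the one comparable step points upward.

Compound 4 is therefore expected to show a weaker result, estimated as a 3.1-fold higher number from compound 1 to compound 4 (0.50 log units; beyond the scatter), giving about 2800 nM with a likely range from 1100 nM to 7000 nM.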

Compound 4, half-maximal inhibitory concentration: 1860 nM
Compound 4: the middle estimate sits 1.5-fold (0.18 log units) above what was measured, within the range that was stated.
By their numbers in this assay, from the lowest: compounds 1, 2 and 4 (each within the scatter of the next, the first and the last beyond it); then compound 3.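

In this assay, pentyl in place of 4-fluorophenyl on a saturated chain carbon bound to an oxygen on an aromatic ring gives a 2.1-fold higher number from compound 1 to compound 4 (0.32 log units; beyond the scatter). This is a second case of the 4-fluorophenyl giving way to a chain with no ring and the number rising beyond the scatter, as methyl did in a 5.3-fold higher number from compound 2 to compound 3 (0.72 log units; beyond the scatter), and no compound shown goes against this. Nothing available explains why the number rises with this change.

The two chains sit on compounds with different amine side chains, so these compounds cannot show whether the number depends on chain length. Going by these compounds, it also remains open whether a cyclohexyl ring or a pentyl chain ending in an amine would bring the number back towards that of compound 1.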